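Chloro for Fluoro: Expecting the Fourth Compound's Cytotoxicity

The source may hold more compounds than are shown below. What is called first, only, known or untested is meant among the compounds shown, and "the series" means these compounds.

Of the compounds shown here, three have been measured in a functional assay on PC-3 cells (Homo sapiens) for cytotoxicity, read by MTT assay, with a stated time of 72 h; on this read-out lower numbers stand for stronger inhibition and higher numbers for weaker inhibition.

Compound 1 `O=S(=O)(c1ccccc1)c1nc2ccccc2nc1Nc1ccc(F)cc1`: 14200 nM
Compound 2 `O=S(=O)(c1ccccc1)c1nc2ccccc2nc1Nc1ccc(Cl)cc1`: 15300 nM
Compound 3 `O=S(=O)(c1ccc(Br)cc1)c1nc2ccccc2nc1Nc1ccc(F)cc1`: 9160 nM

Compound 4 `O=S(=O)(c1ccc(Br)cc1)c1nc2ccccc2nc1Nc1ccc(Cl)cc1` has not yet been measured. The core of compound 3 differs from the core of compound 1 by bromo in place of hydrogen on an aromatic carbon, and the step between them is a 1.6-fold lower number from compound 1 to compound 3 (0.19 log units; within the scatter). Compound 2 differs from compound 1 by chloro in place of fluoro on an aromatic carbon, giving the step of a 1.1-fold higher number from compound 1 to compound 2 (0.03 log units; within the scatter). Compound 4 differs from compound 3 by chloro in place of fluoro on an aromatic carbon; the place of this change is described in the same words as for the earlier pair, so it is the same change, now made on the core of compound 3. Within the data shown here, the step from compound 1 to compound 2 stayed within the usual scatter, and only this single earlier instance of the change is available to lean on. For compound 4 the step expected in this assay is therefore a 1.1-fold higher number from compound 3 to compound 4 (0.03 log units; within the scatter), resting on that one earlier pair. The estimate for compound 4 is 9900 nM, with a likely range from 5500 nM to 18000 nM.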

Compound 4, half-maximal inhibitory concentration: 7460 nM
The estimate for compound 4 lay 1.3-fold (0.12 log units) above the measured number; low and high end bracket the measured number.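

In this assay, chloro in place of fluoro gives a 1.2-fold lower number from compound 3 to compound 4 (0.09 log units; within the scatter), which matches what the same change did on the other core: the same change on two cores in this assay, a 1.1-fold higher number (0.03 log units; within the scatter) from compound 1 to compound 2 and a 1.2-fold lower number (0.09 log units; within the scatter) from compound 3 to compound 4, 1.3-fold (0.12 log units) apart, within the scatter of two such steps. Bromo in place of hydrogen gives a 2.1-fold lower number from compound 2 to compound 4 (0.31 log units; beyond the scatter), and this step also agrees with its earlier instance, even though only the newer step lies beyond the scatter: the same change on two cores in this assay, a 1.6-fold lower number (0.19 log units; within the scatter) from compound 1 to compound 3 and a 2.1-fold lower number (0.31 log units; beyond the scatter) from compound 2 to compound 4, 1.3-fold (0.12 log units) apart, within the scatter of two such steps. Both changes therefore carried from one core to the other among these four compounds, with chloro for fluoro making no readable difference on either core, but each comparison rests on just two pairs and shows neither why the steps agree nor whether they would hold on a different core.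

At the two places that change, the compounds shown carry only hydrogen, fluoro, chloro or bromo, so it remains open whether an amine, a methoxy group or a carboxylic acid would fit the same picture. Whether these small steps would also appear in other cell lines is open as well.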